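A few compounds are considered here, and "the series" means these few. Any claim that something is new, unique, unknown or untested is made for them only; others in the source may bear on it.

Measured compounds and their numbers:
- compound 1, `CCCCCCCC/C=C\c1c(C)c(/C=C/CCCCCCCC)c2[n+](c1C)CCC2`, gives 3.7 uM
- compound 2, `CCCCCCCC/C=C\c1c(C)c(/C=C\CCCCCCCC)c2[n+](c1C)CCC2`, gives 22.7 uM
- compound 3, `CCCCCCCCCCc1c(C)c(CCCCCCCCCC)c2[n+](c1C)CCC2`, gives 2.8 uM

In an ADME assay on NIH3T3 cells (Mus musculus) for cytotoxicity, read by neutral red uptake, with a stated time of 48 h (on this read-out lower numbers stand for higher toxicity in this test and higher numbers for lower toxicity in this test), compound 1 sits second highest of the three numbers. Its nearest neighbour is compound 3, whose 2.8 uM lies within the scatter of the number of compound 1, so no order between the two can be claimed. Its furthest neighbour is compound 2, and here a step is known: a 6.1-fold higher number from compound 1 to compound 2 (0.79 log units; beyond the scatter). Within the data shown here, that step rests on the fact that compounds 1 and 2 differ only in the configuration as drawn and stands as the only measured example of what a change of drawn configuration does in this set.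

Compound 4, `CCCCCCCC/C=C\c1c(C)c(/C=C/CCCCCCCC)c(C)[n+]2c1CCC2`, has not yet been measured. It differs from compound 1 in this way: the two compounds have the same atoms and bonds and differ only in configuration as drawn: 2 of 2 stereo elements differ; a double bond is drawn E in compound 1 and Z in compound 4; a double bond is drawn Z in compound 1 and E in compound 4. The step from compound 1 to compound 2 turned one double bond from E to Z and moved the number upward, towards lower toxicity. Compound 4 carries that same turn together with the reverse turn at the other double bond, so the measured step bears on it only in part. An upward move of modest size is therefore expected, smaller than the measured one, since the second turn runs the opposite way. The expected step is a 2.4-fold higher number from compound 1 to compound 4 (0.39 log units; beyond the scatter). For compound 4 the estimate is 9 uM, with a range from 3 uM to 30 uM.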

Compound 4, half-maximal toxic concentration: 3.2 uM
Compound 4: middle estimate off by 2.8-fold (0.45 log units), on the high side, within the range that was stated.
By their numbers in this assay, from the lowest: compounds 3, 4 and 1 (each within the scatter of the next); then compound 2.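

Compound 4 shows that exchanging the E and Z drawings between the two double bonds makes no readable difference in this assay: a 1.2-fold lower number from compound 1 to compound 4 (0.06 log units; within the scatter). The earlier compounds had shown the effect of turning only one double bond, whereas compound 4 adds the turn at the other one, and that turn from Z to E also gives a clear change: a 7.1-fold lower number from compound 2 to compound 4 (0.85 log units; beyond the scatter). Among these three isomers, then, the two that carry one E and one Z double bond stay within the scatter of each other, and compound 2, with both drawn Z, stands apart from each of them, a gap that can be laid to configuration alone because nothing else separates compounds 2 and 4: the fact that compounds 2 and 4 differ only in the configuration as drawn.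

The compounds shown leave open where an isomer with both double bonds drawn E would fall, and so whether a second E double bond changes the number any further. They also leave open whether the gap between these isomers would persist with a longer chain, or with an amine or a carboxylic acid at the end of each chain.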